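The source may report more compounds than this note shows. Statements on the series, on what has been measured and on what is new or still open speak of the compounds shown alone.

Measured in a functional assay on HepG2 cells (Homo sapiens) for antiproliferative activity, read by sulforhodamine B assay, with a stated time of 48 h; on this read-out lower numbers stand for stronger inhibition and higher numbers for weaker inhibition
- compound 1 `COc1cccc(C(=O)C(O)C(Nc2ccc(F)c(Cl)c2)c2ccc(Br)cc2)c1` gives 37.2 nM
- compound 2 `COc1ccc(C(=O)C2OC2c2ccc(Cl)cc2)cc1` gives 15 nM

Compound 2 at 15 nM is the lower of the two numbers, beyond the scatter from compound 1. Compound 3 `COc1ccc(C(=O)C2OC2c2ccc(Br)cc2)cc1` follows from compound 2 through bromo in place of chloro on an aromatic carbon with bromo in place of chloro on an aromatic carbon, para to a large group. Among the compounds with values here, no measured pair shows this exchange, so in this assay a step within the scatter is expected, in neither direction. The estimated step, a 1.1-fold higher number from compound 2 to compound 3 (0.03 log units; within the scatter), stays small. Compound 3 is expected at 16 nM with an estimated range from 7 nM to 38 nM for this measurement.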

Compound 3, half-maximal inhibitory concentration: 30 nM
The estimate for compound 3 lay 1.9-fold (0.27 log units) below the measured number; measured number inside the range.
By their numbers in this assay, from the lowest: compounds 2, 3 and 1 (each within the scatter of the next, the first and the last beyond it).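

In this assay, bromo in place of chloro on an aromatic carbon, para to a large group, gives a 2.0-fold higher number from compound 2 to compound 3 (0.30 log units; within the scatter), so this position accepts either halogen with no step beyond the scatter. Within the data shown here, this is the first direct reading of any single change, since compound 1 and compound 2 differ in more than one place. No supporting data bear on the reason for this result. The compounds shown leave open how this position responds to a non-halogen group, such as an amine or a carboxylic acid.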